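Swapping chloro for trifluoromethyl on an anilino-quinazoline

The compounds below may be only part of what the source reports. "The series", "measured", "known", "first", "only" and "open" are said of these compounds alone.

Three compounds share one core and differ only in the aryl group on the anilino nitrogen. Compound 1 `C=CC(=O)Nc1cccc(NC(=O)CSc2nc(Nc3cccc(OC)c3)c3ccccc3n2)c1` gives 34900 nM in a functional assay on PC-3 cells (Homo sapiens) for inhibition, read by MTT assay, with a stated time of 72 h; a higher number here means a weaker inhibitor, a lower number a stronger inhibitor. Compound 2 `C=CC(=O)Nc1cccc(NC(=O)CSc2nc(Nc3ccc(F)cc3)c3ccccc3n2)c1` gives 8240 nM in this assay, and compound 3 `C=CC(=O)Nc1cccc(NC(=O)CSc2nc(Nc3ccc(Cl)cc3)c3ccccc3n2)c1` gives 10800 nM. Compound 3 thus stands second highest of the three numbers: one step is a 1.3-fold higher number from compound 2 to compound 3 (0.12 log units; within the scatter), which stays within the scatter, another is a 3.2-fold lower number from compound 1 to compound 3 (0.51 log units; beyond the scatter), and a third is a 4.2-fold lower number from compound 1 to compound 2 (0.63 log units; beyond the scatter).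

Compound 4 `C=CC(=O)Nc1cccc(NC(=O)CSc2nc(Nc3ccc(C(F)(F)F)cc3)c3ccccc3n2)c1` is compound 3 with one change: trifluoromethyl in place of chloro on an aromatic carbon. For the measured compounds named here, the only step that touches the same position, fluoro to chloro, changed nothing beyond the scatter, so the nearest evidence is that exchanging one small group for another at this place leaves the number roughly where it is. Compound 4 is therefore expected to give about 11000 nM, between 4500 nM and 28000 nM, which would be a step of a 1.0-fold higher number from compound 3 to compound 4 (0.01 log units; within the scatter) and is expected to stay within the scatter.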

Compound 4, half-maximal inhibitory concentration: 12500 nM
For compound 4 the middle estimate is 1.1-fold (0.06 log units) below the measured one; low and high end bracket the measured number.
By their numbers in this assay, from the lowest: compounds 2, 3 and 4 (each within the scatter of the next); then compound 1.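

Trifluoromethyl brings 4 heavy atoms where chloro has 1, yet the change gives a 1.2-fold higher number from compound 3 to compound 4 (0.06 log units; within the scatter) in this assay and stays within the scatter. The step from the fluoro compound, a 1.5-fold higher number from compound 2 to compound 4 (0.18 log units; within the scatter), also stays within it, so fluoro, chloro and trifluoromethyl on this aromatic carbon cannot be told apart by this read-out, even though the entering group is clearly larger in atom count. Compound 4 also joins the other two on the same side of the 3-methoxyphenyl compound, with a 2.8-fold lower number from compound 1 to compound 4 (0.45 log units; beyond the scatter), so all three 4-substituted phenyl groups give lower numbers than compound 1.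

No measurement here accounts for this flat response. On these data alone, whether an amine, a carboxylic acid or a longer chain on the same carbon would shift the number remains open.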